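Shortening the isobutyl chain of compound 2

This account rests on a few compounds, and the source may have more. Where it says the series, first, only, none or still open, it means among the compounds named here.

In a physicochemical assay for lipophilicity, using the shake flask method, in phosphate buffer, with a stated time of 1 h (a higher number here means a more lipophilic compound, a lower number a more polar compound), compound 2 (`CC(C)CC(=O)OC[C@H]1O[C@@H](n2cnc3c(N)ncnc32)[C@@H](O)[C@@H]1O`) gives 1.39 and stands level, within the usual scatter, with compound 1 (`CCCCC(=O)OC[C@H]1O[C@@H](n2cnc3c(N)ncnc32)[C@@H](O)[C@@H]1O`), which gives 1.33 on the same scale. Compound 3 (`CCCC(=O)OC[C@H]1O[C@@H](n2cnc3c(N)ncnc32)[C@@H](O)[C@@H]1O`) has not yet been measured. It carries hydrogen in place of methyl on a saturated chain carbon bound to two saturated chain carbons, so isobutyl becomes propyl.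

Among the compounds with values here, only one measured step is available for comparison. It is a number 0.06 log units higher from compound 1 to compound 2 (within the scatter) and comes from isopropyl in place of propyl on a saturated chain carbon bound to a carbonyl carbon. That step rearranges the chain without shortening it, so it gives no direct size for the change at hand. Even so, a shorter chain leads to the expectation of a lower number in this assay and of a drop larger than the scatter. The expected size is a number 0.49 log units lower from compound 2 to compound 3 (beyond the scatter) and it rests on the structural change alone, so the range is kept wide. In this assay compound 3 is estimated at 0.9 with a range from 0.6 to 1.2 as the expected span.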

Compound 3, partition coefficient: 0.9
For compound 3 middle estimate and measured number coincide at the digits printed, and the stated range covers the measured number.
By their numbers in this assay, from the lowest: compound 3; then compounds 1 and 2 (each within the scatter of the next).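

In this assay, within the data shown here, the loss of one methyl that turns isobutyl into propyl gives a number 0.49 log units lower from compound 2 to compound 3 (beyond the scatter), and this is the first step to lie beyond the scatter. The straight chain, losing a methyl on a saturated chain carbon three bonds along the chain from a carbonyl carbon, gives a number 0.43 log units lower from compound 1 to compound 3 (beyond the scatter), so both starting chains move in the same direction when they end up as the same shorter chain. Rearranging the chain had left the number within the scatter, whereas these two steps show that removing a carbon from this chain does move it, although nothing measured here gives a reason for the change.

With only these three chains side by side, it remains open whether the number would keep falling with a still shorter chain, such as an ethyl group, or rise further with a chain longer than those shown. Also open, on these data alone, is what a quite different group on this chain, such as an amine or a carboxylic acid, would do to the number on the same scale.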